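A few compounds are considered here, and "the series" means these few. Any claim that something is new, unique, unknown or untested is made for them only; others in the source may bear on it.

Compound 1 `O=C1NC(c2ccccc2)=C([N+](=O)[O-])C(c2cccnc2)N1`: 0.035 mg/kg
Compound 2 `O=C1NC(c2ccccc2)=C([N+](=O)[O-])C(c2ccccc2)N1`: 0.035 mg/kg

In an in vivo functional assay on the whole organism (heart) with Rattus norvegicus as the target (a higher number here means that more compound is needed for the effect, a lower number that less compound is needed), compound 2 gives 0.035 mg/kg, level with compound 1, which gives 0.035 mg/kg. Within the data shown here, the one measured step, no change at the digits printed from compound 1 to compound 2 (within the scatter), stayed within the scatter. Compound 3 `O=C1NC(c2ccccc2)=C([N+](=O)[O-])C(c2cccc(F)c2)N1` carries the difference (fluoro in place of hydrogen on an aromatic carbon), a change at the same aromatic ring that the earlier step exchanged wholesale without effect. Among the measured compounds shown here, no measured step speaks to fluorine on that ring; the only comparison available argues for tolerance. Compound 3 is therefore expected to lie with compound 2, a step of no change at the digits printed from compound 2 to compound 3 (within the scatter), at about 0.035 mg/kg (range 0.015 mg/kg to 0.08 mg/kg).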

Compound 3, minimum effective dose: 0.00035 mg/kg
For compound 3 the middle estimate is 100-fold (2.00 log units) above the measured one, and the stated range ends above it.
By their numbers in this assay, from the lowest: compound 3; then compounds 1 and 2 (each within the scatter of the next).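

In this assay, the aromatic ring on the saturated ring carbon proved far from indifferent: fluoro in place of hydrogen gives a 100-fold lower number from compound 2 to compound 3 (2.00 log units; beyond the scatter), and 3-fluorophenyl in place of pyridin-3-yl gives a 100-fold lower number from compound 1 to compound 3 (2.00 log units; beyond the scatter). The earlier exchange of the whole ring had shown no such sensitivity, so a single added atom at this aromatic carbon did what that exchange did not. No evidence here bears on why the step is so large. The compounds shown leave open whether chloro, methyl or methoxy at this carbon would give a similar step, and whether fluoro elsewhere on the ring would do so.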